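This account rests on a few compounds, and the source may have more. Where it says the series, first, only, none or still open, it means among the compounds named here.

Working notes on the series.

Compound 1 `O=c1[nH]/c(=N\OCCCCc2ccccc2)ccn1[C@@H]1O[C@H](COP(=O)(O)OP(=O)(O)OP(=O)(O)O)[C@@H](O)[C@H]1O` is the reference point; in a functional assay on 1321-N1 cells for agonist activity at P2Y purinoceptor 2 (Homo sapiens), read by scintillation counting and inositol phosphate accumulation (a higher number here means that more compound is needed for the effect, a lower number that less compound is needed), compound 1 gives 214 nM. Two analogues replace the benzyl end of the chain. Compound 2 `O=c1[nH]/c(=N\OCCCc2cccc(I)c2)ccn1[C@@H]1O[C@H](COP(=O)(O)OP(=O)(O)OP(=O)(O)O)[C@@H](O)[C@H]1O` gives 325 nM in this assay, and compound 3 `O=c1[nH]/c(=N\OCCCc2cccnc2)ccn1[C@@H]1O[C@H](COP(=O)(O)OP(=O)(O)OP(=O)(O)O)[C@@H](O)[C@H]1O` gives 327 nM. Neither number separates from compound 1 beyond the usual scatter: the step of a 1.5-fold higher number from compound 1 to compound 2 (0.18 log units; within the scatter) and the step of a 1.5-fold higher number from compound 1 to compound 3 (0.18 log units; within the scatter) are both small, and between the two analogues the step of a 1.0-fold higher number from compound 2 to compound 3 (0.00 log units; within the scatter) is flat. So far, then, exchanging the benzyl for a 3-iodophenyl or a pyridin-3-yl leaves the read-out essentially where compound 1 puts it.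

Compound 4 `O=c1[nH]/c(=N\OCCCc2ccncc2)ccn1[C@@H]1O[C@H](COP(=O)(O)OP(=O)(O)OP(=O)(O)O)[C@@H](O)[C@H]1O` is the next member. Its difference from compound 1: pyridin-4-yl in place of benzyl on a saturated chain carbon, three bonds along the chain from an oxygen. Among the compounds with values here, the closest precedent is compound 3, where the pyridin-3-yl entered in the same place and the step of a 1.5-fold higher number from compound 1 to compound 3 (0.18 log units; within the scatter) stayed within the scatter; compound 2 with the step of a 1.5-fold higher number from compound 1 to compound 2 (0.18 log units; within the scatter) points the same way. On that basis the number for compound 4 in this assay is expected to stay close to compound 1, with no step beyond the scatter in either direction, the estimated step being a 1.4-fold higher number from compound 1 to compound 4 (0.15 log units; within the scatter). The estimate for compound 4 is 300 nM, with a range from 130 nM to 700 nM.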

Compound 4, half-maximal effective concentration: 285 nM
Compound 4: the middle estimate sits 1.1-fold (0.02 log units) above what was measured; low and high end bracket the measured number.
By their numbers in this assay, from the lowest: compounds 1, 4, 2 and 3 (each within the scatter of the next).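

In this assay, the place on a saturated chain carbon, three bonds along the chain from an oxygen, now gives no separation between the two pyridines, with a 1.1-fold lower number from compound 3 to compound 4 (0.06 log units; within the scatter), so the location of the ring nitrogen in these two groups does not register in this read-out. The comparison with the carbon-only ring gives a 1.3-fold higher number from compound 1 to compound 4 (0.12 log units; within the scatter), and that with the iodinated ring gives a 1.1-fold lower number from compound 2 to compound 4 (0.06 log units; within the scatter), which places all four compounds within the scatter of one another and extends the flat picture to a second pyridine. No independent data accompany these numbers to account for this flat result.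

On these data alone, whether a pyridin-2-yl, an amine, a carboxylic acid or a chain longer than 4-phenylbutyl in the same place would produce a step beyond the scatter remains open. With every step among these four compounds inside the scatter, the series does not yet show which structural change at this place, if any, can move the number in this assay.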